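This account rests on a few compounds, and the source may have more. Where it says the series, first, only, none or still open, it means among the compounds named here.

Compound 3 `CCN1CCN(CC(=O)Nc2ccc(-c3nc(-c4ccccc4)c(-c4ccccc4)n3C)cc2)CC1` gives 7.4% in a functional assay on HT-29 cells (Homo sapiens) for cytotoxicity, read by MTT assay, with a stated time of 24 h, tested at 0.64 ug/mL (a lower number here means a weaker effect, a higher number a stronger effect of the compound at the concentration tested), the lowest of the three numbers. Compound 2 `Cc1ccc2oc(SCC(=O)Nc3ccc(-c4nc(-c5ccccc5)c(-c5ccccc5)n4C)cc3)nc2c1` gives 11%, and the step of a number 3.6 percentage points lower from compound 2 to compound 3 (within the scatter) lies within the scatter. Compound 1 `Cn1c(-c2ccc(NC(=O)CSc3nc4ccccc4o3)cc2)nc(-c2ccccc2)c1-c1ccccc1` gives 24.8%, and the step of a number 17.4 percentage points lower from compound 1 to compound 3 (beyond the scatter) lies beyond it, as does a number 13.8 percentage points lower from compound 1 to compound 2 (beyond the scatter). Compound 4 `COc1ccc(CN2CCN(CC(=O)Nc3ccc(-c4nc(-c5ccccc5)c(-c5ccccc5)n4C)cc3)CC2)cc1` differs from compound 3 by 4-methoxyphenyl in place of methyl on a saturated chain carbon bound to an amine nitrogen in a ring. Within the data shown here, none of the measured steps alters the group on the amine nitrogen in the ring; the two steps that reach compound 3 change the chain carbon bound to the carbonyl carbon instead, so they give no direct guide to this change. Among the measured compounds shown here, with no bearing step, the expected step is a number 2.6 percentage points higher from compound 3 to compound 4 (within the scatter), none beyond the scatter. Compound 4 is therefore estimated at 10%, within 2% to 24%.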

Compound 4, a percentage reported as activity, at one concentration (the size of the read-out at that concentration, not a potency): 5.2%
Compound 4: the middle estimate sits 4.8 percentage points above what was measured, and the stated range covers the measured number.
By their numbers in this assay, from the lowest: compounds 4, 3 and 2 (each within the scatter of the next); then compound 1.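

Swapping methyl for 4-methoxyphenyl on a saturated chain carbon bound to an amine nitrogen in a ring, which turns ethyl into 4-methoxybenzyl, gives a number 2.2 percentage points lower from compound 3 to compound 4 (within the scatter) in this assay. Among these compounds, this is the first measured change at this position, and a group of 8 heavy atoms with a six-membered aromatic ring in place of 1 heavy atom leaves the read-out within the scatter. Nothing measured gives a reason for this. On these data alone, whether an unsubstituted benzyl, a carboxylic acid or a primary amine at this place would read differently stays open.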